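The source may report more compounds than this note shows. Statements on the series, on what has been measured and on what is new or still open speak of the compounds shown alone.

Working notes on the series.

Compound 1 `Oc1ccc(-c2cc(-c3cccc(Cl)c3)nc(-c3ccccn3)c2)cc1` gives 59.4% in an assay on isolated protein for inhibition of DNA topoisomerase 1 (Homo sapiens), with a stated time of 30 min, tested at 100 uM; a lower number here means a weaker effect, a higher number a stronger effect of the compound at the concentration tested. Compound 2 `Oc1cccc(-c2cc(-c3cccc(Cl)c3)nc(-c3ccccn3)c2)c1` differs from compound 1 by 3-hydroxyphenyl in place of 4-hydroxyphenyl on an aromatic carbon, and in this assay compound 2 gives 0.4%; the step is a number 59 percentage points lower from compound 1 to compound 2 (beyond the scatter). Compound 3 `Oc1ccc(-c2cc(-c3ccc(Cl)cc3)nc(-c3ccsc3)c2)cc1` has a different core; the difference between the two cores is not broken down here. In this assay compound 3 gives 47.7%, which stands second of the three measured numbers.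

Compound 4 `Oc1cccc(-c2cc(-c3ccc(Cl)cc3)nc(-c3ccsc3)c2)c1`, not yet measured, differs from compound 3 by 3-hydroxyphenyl in place of 4-hydroxyphenyl on an aromatic carbon. This is the same kind of change as from compound 1 to compound 2, though the surroundings differ: in compound 1 the place is meta to a 3-chlorophenyl group and meta to a pyridin-2-yl group, in compound 3 it is meta to a 4-chlorophenyl group and meta to a thiophen-3-yl group. For the measured compounds named here, with only one measured instance of the change, the expectation rests on that single step, a number 59 percentage points lower from compound 1 to compound 2 (beyond the scatter), and a drop of similar size is expected. The expected step is a number 41.7 percentage points lower from compound 3 to compound 4 (beyond the scatter). Compound 4 is therefore expected to give about 6%, estimated between 0% and 28%.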

Compound 4, a percentage reported as inhibition, at one concentration (the size of the read-out at that concentration, not a potency): 11.7%
For compound 4 the middle estimate is 5.7 percentage points below the measured one; measured number inside the range.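

On the core of compound 3, 3-hydroxyphenyl in place of 4-hydroxyphenyl gives a number 36 percentage points lower from compound 3 to compound 4 (beyond the scatter) in this assay, so the direction of the earlier step carries over to this second core. The size of the step does not carry over unchanged: the same change on two cores in this assay, a number 59 percentage points lower (beyond the scatter) from compound 1 to compound 2 and a number 36 percentage points lower (beyond the scatter) from compound 3 to compound 4, 23 percentage points apart, beyond the scatter of two such steps. Compound 1 and compound 3 differ in more than one place, so the gap between the two steps cannot be assigned to the chlorophenyl group or to the pyridin-2-yl and thiophen-3-yl groups, and two cores give no rule for a third.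

The compounds shown leave open how an amine, a carboxylic acid or a methoxy group would read in place of the hydroxyl on the phenyl ring. Also open, as far as these compounds go, is the size of the step on a core that pairs a 3-chlorophenyl group with a thiophen-3-yl group or a 4-chlorophenyl group with a pyridin-2-yl group, which would separate those two places.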